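A few compounds are considered here, and "the series" means these few. Any claim that something is new, unique, unknown or untested is made for them only; others in the source may bear on it.

Compound 1 `COc1ccc(F)cc1Nc1cc(NC(=O)Nc2c(Cl)cccc2Cl)ncn1` gives 31.3% in a functional assay on NCI-H226 cells (Homo sapiens) for inhibition, read by MTT assay, with a stated time of 48 h, tested at 10 uM (a higher number here means more inhibition at the concentration tested (going by the name of the read-out), a lower number less inhibition), the lowest of the three numbers measured, though within the usual scatter of both compound 3 `COc1cc(NC(=O)Nc2cc(Nc3ccc(F)c(Cl)c3)ncn2)cc(OC)c1` with 36.7% and compound 2 `COc1cc(NC(=O)Nc2cc(Nc3cccc(C(C)(C)C)c3)ncn2)cc(OC)c1` with 40%. Within the data shown here, the only measured step, a number 3.3 percentage points lower from compound 2 to compound 3 (within the scatter), concerns an exchange of the aryl group on a nitrogen on an aromatic ring and stays within the scatter. Compound 4 `COc1ccc(Br)cc1Nc1cc(NC(=O)Nc2c(Cl)cccc2Cl)ncn1` differs from compound 1 by bromo in place of fluoro on an aromatic carbon. Among the measured compounds shown here, no measured step bears on a halogen exchange at that place, so the measured data give no ground to expect a shift beyond the scatter. For compound 4 the expected step is a number 1.7 percentage points higher from compound 1 to compound 4 (within the scatter). Compound 4 is therefore estimated at 33%, with a range from 18% to 48%.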

Compound 4, a percentage reported as inhibition, at one concentration (the size of the read-out at that concentration, not a potency): 33%
Compound 4: the middle estimate sits on the measured number at the digits printed; low and high end bracket the measured number.
By their numbers in this assay, from the lowest: compounds 1, 4, 3 and 2 (each within the scatter of the next).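

Among these compounds, the exchange in the 5-fluoro-2-methoxyphenyl group gives a number 1.7 percentage points higher from compound 1 to compound 4 (within the scatter) in this assay and is the first step measured at this position. It shows that, on the core of compound 1, fluoro and bromo at this place para to a methoxy group give numbers within the scatter of each other. Nothing available explains this result or links it to any property of either halogen. The compounds shown leave open whether an amine, a carboxylic acid or a longer chain at this place would give a step beyond the scatter.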